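The compounds below may be only part of what the source reports. "The series", "measured", "known", "first", "only" and "open" are said of these compounds alone.

Measured compounds, with their values in a functional assay on KB cells (Homo sapiens) for inhibition; on this read-out lower numbers stand for stronger inhibition of growth and higher numbers for weaker inhibition of growth:
Compound 1 `Cc1cccc2sc(NC(=O)COc3ccc(/C=C4\SC(=O)NC4=O)cc3)nc12` gives > 100000 nM in this assay, which is a limit of the assay and not a number.
Compound 2 `O=C(COc1ccc(/C=C2\SC(=O)NC2=O)cc1)Nc1ccc([N+](=O)[O-])cc1` gives > 100000 nM in this assay, again a limit of the assay.
Compound 3 `O=C(COc1ccc(/C=C2\SC(=O)NC2=O)cc1)Nc1cccc([N+](=O)[O-])c1` gives > 100000 nM in this assay, again a limit of the assay.

Compound 2 therefore stands at the limit of this assay rather than at a number, and the two further values shown are limits as well, so compound 2 can only be placed alongside them, not ranked against them. Going by the values given here, the single step between measured compounds that differ in one place, a step that the two limits leave unreadable from compound 2 to compound 3, has limits at both ends and its size cannot be read. What the series shows is summed up by the limit of > 100000 nM in this assay, at which 3 of the 3 values shown sit.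

Compound 4 `O=C(COc1ccc(/C=C2\SC(=O)NC2=O)cc1)Nc1ccccc1` differs from compound 2 in this way: hydrogen in place of nitro on an aromatic carbon. Among the compounds with values here, no measured step bears on this change; the only substituent comparison on the same phenyl, from compound 2 to compound 3, is unreadable. Within the data shown here, since every value so far sits at the limit, as the limit of > 100000 nM in this assay, at which 3 of the 3 values shown sit, states, compound 4 is expected to sit there too. The estimate for compound 4 in this assay is 150000 nM, with a range from 30000 nM to 600000 nM. The step that the limit leaves unreadable from compound 2 to compound 4 is thus expected to be none beyond the scatter, most likely reported as a limit.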

Compound 4, concentration for 50% growth inhibition: > 100000 nM
Compound 4: only a limit was reported (the forecaster's own chance of this, stated with the estimate: 80%); the middle value lies beyond the limit too.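

Compound 4 gives > 100000 nM in this assay, a limit of the assay and not a number. The steps to compound 4 from compound 2 and from compound 3 have limits at both ends and cannot be read: the limit of > 100000 nM in this assay, at which 4 of the 4 values shown sit.

The compounds shown leave open whether hydrogen in place of nitro changes growth inhibition at all.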